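Working notes: swapping the 4-hydroxycyclohexyl amide for methyl

The compounds below may be only part of what the source reports. "The series", "measured", "known", "first", "only" and "open" are said of these compounds alone.

Compound 1 `CNC(=O)c1cc(C(=O)N[C@H]2CC[C@H](O)CC2)cc2c1OC[C@@]2(C)c1ccccc1` reads >= 161 ug/mL as a limit
Compound 2 `CNC(=O)c1cc(C(N)=O)cc2c1OC[C@H]2c1ccccc1` reads >= 144 ug/mL as a limit

In a physicochemical assay for solubility (a higher number here means a more soluble compound, a lower number a less soluble compound), compound 1 stands at >= 161 ug/mL as a limit and not as a number. Compound 2 gives >= 144 ug/mL as a limit too. The two cannot be ranked. Compound 3 `CNC(=O)c1cc(C(=O)NC)c2c(c1)[C@](C)(c1ccccc1)CO2` is not yet measured and carries methyl in place of 4-hydroxycyclohexyl on an amide-type nitrogen relative to compound 1. For the measured compounds named here, no measured step guides this change, so only a small downward move in this assay is expected, estimated as an at least 1.6-fold lower number from compound 1 to compound 3 (0.20 log units; that floor lies within the scatter) and not clearly beyond the scatter. For compound 3 the estimated value is 100 ug/mL with an expected range of 35 ug/mL to 200 ug/mL in this measurement.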

Compound 3, solubility: >= 132 ug/mL
Compound 3: a limit, no number; the forecaster's own chance of this, stated with the estimate: 45%; at least 1.3-fold (0.12 log units) between middle value and limit.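

In this assay compound 3 gives >= 132 ug/mL, a limit and not a number. For the compounds shown here, compound 1 is also only a limit, and no step from compound 1 to compound 3 can be read. The compounds shown leave open whether, and how far, methyl in place of 4-hydroxycyclohexyl on an amide-type nitrogen shifts solubility.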